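A Methoxy Step Seen Once, Expected Once More

The compounds below may be only part of what the source reports. "The series", "measured", "known", "first", "only" and "open" are said of these compounds alone.

Three compounds with a shared core were measured in a functional assay on Hs-578T cells (Homo sapiens) for inhibition, read by sulforhodamine B assay, with a stated time of 48 h; on this read-out higher numbers stand for weaker inhibition of growth and lower numbers for stronger inhibition of growth. Compound 1 `COc1cc(-c2cc(/C=C/C(=O)c3ccc(N)cc3)[nH]n2)cc(OC)c1OC` reaches only a limit of the assay, > 100000 nM, and not a number. Compound 3 `COc1ccc(-c2cc(/C=C/C(=O)c3ccc(N)cc3)[nH]n2)cc1OC` likewise sits at a limit, > 100000 nM. For the measured compounds named here, compound 2 `COc1ccc(C(=O)/C=C/c2cc(-c3cc(OC)c(OC)c(OC)c3)n[nH]2)cc1OC` gives 8200 nM in this assay, the only number among the three.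

Compound 3 and compound 1 differ by one change, (methoxy in place of hydrogen on an aromatic carbon). The step that the two limits leave unreadable from compound 3 to compound 1 cannot be read because of the limit of > 100000 nM in this assay, at which 2 of the 3 values shown sit. From compound 1 to compound 2 the change is 3,4-dimethoxyphenyl in place of 4-aminophenyl on a carbonyl carbon, and the step is an at least 12-fold lower number from compound 1 to compound 2 (1.08 log units; beyond the scatter). How compound 2 and compound 3 differ is not broken down here.

Compound 4 `COc1cc(C(=O)/C=C/c2cc(-c3cc(OC)c(OC)c(OC)c3)n[nH]2)cc(OC)c1OC` has not yet been measured in this assay. It differs from compound 2 by methoxy in place of hydrogen on an aromatic carbon, the same change as from compound 3 to compound 1, with the place described in the same words. Going by the values given here, the earlier step, a step that the two limits leave unreadable from compound 3 to compound 1, offers no readable size, so the expectation for compound 4 rests on compound 2 alone, whose value 8200 nM is the one number available. The step from compound 2 to compound 4 is expected to be a 1.4-fold lower number from compound 2 to compound 4 (0.14 log units; within the scatter), a small one within the usual scatter. Compound 4 is therefore estimated at 6000 nM, with a range expected from 2000 nM to 25000 nM.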

Compound 4, concentration for total growth inhibition: 53900 nM
For compound 4 the middle estimate is 9.0-fold (0.95 log units) below the measured one; measured number above the stated range.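

In this assay, methoxy in place of hydrogen on an aromatic carbon, here ortho to a methoxy group on the 3,4-dimethoxyphenyl group, gives a 6.6-fold higher number from compound 2 to compound 4 (0.82 log units; beyond the scatter), so on this core the change goes with weaker inhibition of growth by a modest step beyond the scatter. The same change on the core with the 4-aminophenyl group gives no readable size, because both compounds of that step sit at a limit of the assay and neither gives a number: the limit of > 100000 nM in this assay, at which 2 of the 4 values shown sit. The series therefore shows the size of this change once, on a single core, and it shows neither agreement nor disagreement between the two cores, so nothing here supports carrying this step from one core to the other.

The compounds shown leave open whether the weaker inhibition of compound 4 belongs to methoxy itself or would also appear with an ethoxy or hydroxyl group at the same place. They also leave open how large the methoxy step is on the core of compound 3, where a readable size would need both compounds of the pair to give a number rather than a limit.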